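This account rests on a few compounds, and the source may have more. Where it says the series, first, only, none or still open, it means among the compounds named here.

Compound 1 `CCCCCc1ccc(-c2cn(C[C@H](O)[C@H]3OC(=O)C(OCc4ccccc4)=C3OCc3ccccc3)nn2)cc1`: 7460 nM
Compound 2 `O=C1O/C(=C\Cn2cc(-c3cc(C(F)(F)F)cc(C(F)(F)F)c3)nn2)C(OCc2ccccc2)=C1OCc1ccccc1`: > 100000 nM
Compound 3 `COc1ccc(-c2cn(C/C=C3\OC(=O)C(OCc4ccccc4)=C3OCc3ccccc3)nn2)cc1`: > 100000 nM

Three compounds built on one shared core were tested in a functional assay on HepG2 cells (Homo sapiens) for antiproliferative activity, read by MTT assay, with a stated time of 72 h; a lower number here means a stronger inhibitor, a higher number a weaker inhibitor. Among the compounds with values here, compound 1 gives 7460 nM, the only actual number among the three. For compound 2 the assay reports only a limit, > 100000 nM. For compound 3 it likewise reports only a limit, > 100000 nM. The other two readings therefore rest at the limit of > 100000 nM in this assay, at which 2 of the 3 values shown sit, leaving compound 1 as the sole measured reference point.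

Compound 4 `CCCCCCCCCCc1cn(C[C@H](O)[C@H]2OC(=O)C(OCc3ccccc3)=C2OCc2ccccc2)nn1` differs from compound 1 in one place: decyl in place of 4-pentylphenyl on an aromatic carbon. Within the data shown here, no measured pair shows what such a swap does in this assay, so the expected step of a 2.0-fold higher number from compound 1 to compound 4 (0.30 log units; within the scatter) is a guess, leaning toward weaker inhibition but possibly no larger than the scatter. Compound 4 is thus estimated at 15000 nM, within 3000 nM to 90000 nM.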

Compound 4, half-maximal inhibitory concentration: 12200 nM
For compound 4 the middle estimate is 1.2-fold (0.09 log units) above the measured one, within the range that was stated.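

At this aromatic carbon of the five-membered ring, a decyl chain with no ring can stand in for 4-pentylphenyl: in this assay the swap gives a 1.6-fold higher number from compound 1 to compound 4 (0.21 log units; within the scatter). For this pair, then, the six-membered aromatic ring of 4-pentylphenyl is not needed for a measurable reading. Compound 4 joins compound 1 with an actual number rather than a reading at the limit: the limit of > 100000 nM in this assay, at which 2 of the 4 values shown sit.

As far as these compounds go, whether a shorter chain, or a chain ending in an amine or a carboxylic acid, would give a similar reading stays open. Compound 2 and compound 3 each differ from compound 1 in more than one place, so the role of the hydroxyl also remains unresolved.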